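Isopropyl for propyl on the carbonyl: the next step

The source may hold more compounds than are shown below. What is called first, only, known or untested is meant among the compounds shown, and "the series" means these compounds.

The three measured compounds share a tether between two aryl ethers and differ in the acyl group and in the placing of the acid, hydroxy and methyl groups. Compound 1 `Cc1c(OCCCCOc2ccccc2C(=O)O)ccc(C(=O)CC2CCCC2)c1C` gives in an assay on HEK293 cells for positive allosteric modulation of metabotropic glutamate receptor 2 (Rattus norvegicus), read by thallium flux, with a stated time of 2.5 min (on this read-out lower numbers stand for smaller maximal responses and higher numbers for larger maximal responses), a value of 67.1%. Compound 2 `Cc1c(OCCCCOc2ccccc2C(=O)O)ccc(C(=O)CC(C)C)c1O` gives in this assay a value of 92.4%. Compound 3 `CCCC(=O)c1ccc(OCCCCOc2ccc(C(=O)O)cc2C)c(C)c1O` gives in this assay a value of 79.3%. Compound 3 therefore stands second of the three: compound 1 lies below it by a gap beyond the scatter, and compound 2 lies above it by a gap that is also beyond the scatter. Since each pair differs in more than one place, none of these gaps can be assigned to a single change.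

Compound 4 `Cc1cc(C(=O)O)ccc1OCCCCOc1ccc(C(=O)C(C)C)c(O)c1C` is the unmeasured partner of compound 3, differing from it in one place: isopropyl in place of propyl on a carbonyl carbon. Within the data shown here, no measured pair shows this change alone, and the three measured compounds carry it mixed with other changes, so no direction can be read from them. The step of a number 0.7 percentage points higher from compound 3 to compound 4 (within the scatter) is expected to stay within the usual scatter, with no direction favoured. Compound 4 is expected to reach 80%, with the range 62% to 98%.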

Compound 4, largest response reached (reported as percent of maximum), in percent of the reference or control that the assay uses: 76.9%
Estimate against measurement, compound 4: 3.1 percentage points above, and the stated range covers the measured number.
By their numbers in this assay, from the lowest: compounds 1, 4 and 3 (each within the scatter of the next, the first and the last beyond it); then compound 2.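

Isopropyl in place of propyl on a carbonyl carbon can now be read alone for the first time, since the earlier compounds carried this change only mixed with other differences: in this assay the swap gives a number 2.4 percentage points lower from compound 3 to compound 4 (within the scatter) and thus leaves compound 3 and compound 4 not told apart. With the rest of the structure held as in compound 3, this position therefore accepts either of these two chains of the same size, one straight and one branched, without a readable change in maximal response. The data offer no measured basis for explaining why the two groups read alike.

This single pair does not show whether the same swap would read alike on the core of compound 1 or compound 2, where the acid, hydroxy and methyl groups are arranged differently. Also open, going by these compounds, is how far the position stretches beyond these two chains, for example to a longer chain such as pentyl, to a tert-butyl group, to a cyclopropyl ring, or to a chain ending in an amine or a carboxylic acid.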